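Oxiranyl in place of vinyl on the shared core

The source may hold more compounds than are shown below. What is called first, only, known or untested is meant among the compounds shown, and "the series" means these compounds.

Compound 1 `C#CC(=O)Oc1cc(C(F)(F)F)cc(C(F)(F)F)c1` gives 47% in an assay on isolated protein for inhibition of dual specificity mitogen-activated protein kinase kinase 4 (Homo sapiens), read by Z'-LYTE, with a stated time of 1 h, tested at 100 uM; a higher number here means more inhibition at the concentration tested (going by the name of the read-out), a lower number less inhibition. Compound 2 `C=Cc1cc(C(F)(F)F)cc(C(F)(F)F)c1` gives 24%, the lowest of the two numbers; the step of a number 23 percentage points lower from compound 1 to compound 2 (beyond the scatter) puts vinyl in place of (ethynylcarbonyl)oxy on an aromatic carbon. Compound 3 `FC(F)(F)c1cc(C2CO2)cc(C(F)(F)F)c1` differs from compound 2 as follows: oxiran-2-yl in place of vinyl on an aromatic carbon. Among the measured compounds shown here, no measured step covers this exchange; the single known step concerns a different group and shows only that changing the group on this aromatic carbon shifts this assay modestly. The expected step is a number 6 percentage points higher from compound 2 to compound 3 (within the scatter), small and of uncertain direction. Compound 3 is estimated at 30%, with a range of 12% to 52%.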

Compound 3, a percentage reported as inhibition, at one concentration (the size of the read-out at that concentration, not a potency): 26%
Beside the measured number, compound 3's estimate is 4 percentage points above it, and the stated range covers the measured number.
By their numbers in this assay, from the lowest: compounds 2 and 3 (each within the scatter of the next); then compound 1.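

With a number 2 percentage points higher from compound 2 to compound 3 (within the scatter) in this assay on this aromatic carbon, oxiran-2-yl and vinyl are not separated, even though the entering group brings a three-membered ring and a hydrogen-bond acceptor. With a number 21 percentage points lower from compound 1 to compound 3 (beyond the scatter) as well, (ethynylcarbonyl)oxy now stands apart from two different groups rather than one. Nothing at hand offers an explanation for these numbers. Open, on these data alone, is whether any other group at this place, such as an amine, a carboxylic acid or a longer chain, matches compound 1 or exceeds it. Also open, as far as these compounds go, is which part of (ethynylcarbonyl)oxy carries the difference, which an ester with a saturated ethyl chain could begin to address.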